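The compounds below may be only part of what the source reports. "The series", "measured", "known", "first", "only" and "open" are said of these compounds alone.

Four compounds share one core, an oxazole carboxamide joined to a piperazine that carries an aryl group on its far nitrogen. Within the data shown here, compound 1 `COc1ccc(Cl)cc1N1CCN(C(=O)c2oc(C)nc2-c2ccccc2F)CC1` is the only member with a measured number: in a functional assay on HL-60 cells (Homo sapiens) for inhibition, read by MTT assay, with a stated time of 72 h (a higher number here means a weaker inhibitor, a lower number a stronger inhibitor), compound 1 gives 153 nM. Compound 2 `CC(=O)c1ccc(N2CCN(C(=O)c3oc(C)nc3-c3ccccc3)CC2)cc1` stands apart from that: in this assay compound 2 is recorded as "not active" (no number reported), with no number attached, and it is joined in that position by compound 3 `O=C(c1oc(C(F)(F)F)nc1-c1ccc(F)cc1)N1CCN(c2cccc(Cl)c2)CC1`, for which this assay likewise reports "not active" (no number reported). Compound 2 therefore cannot be placed on a scale against compound 1; it is simply below the range where a number was obtained.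

Compound 4 `Cc1nc(-c2ccccc2)c(C(=O)N2CCN(c3cccc(C(F)(F)F)c3)CC2)o1` has not yet been measured. It differs from compound 2 in one place: 3-(trifluoromethyl)phenyl in place of 4-acetylphenyl on an amine nitrogen in a ring. The rest of the molecule, the methyl on the oxazole and the unsubstituted phenyl, is kept. Among the measured compounds shown here, with no measured pair of this kind, the size of the step from compound 2 to compound 4 in this assay can only be guessed; a move toward a measurable number is expected, though it may remain beyond the scatter in either direction. The expectation for compound 4 in this assay is 3000 nM, within a range from 400 nM to 30000 nM.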

Compound 4, half-maximal inhibitory concentration: 153 nM
For compound 4 the middle estimate is 20-fold (1.29 log units) above the measured one, outside the stated range (below it).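

Among these compounds, compound 2 has no number in this assay, so the change from compound 2 to compound 4 gives no step that can be read. The compounds shown leave open how much replacing 4-acetylphenyl with 3-(trifluoromethyl)phenyl, taken alone, changes activity. No supporting data here bear on this result.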